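The compounds below may be only part of what the source reports. "The series", "measured", "known", "first", "only" and "open" are said of these compounds alone.

In a physicochemical assay for acid dissociation, compound 1 `Cc1nc2c(CCc3ccccc3)cccn2c1N` gives 7.3. Compound 2 `Cc1nc2c(CCc3ccccc3)cccn2c1C` differs from it in one place, by methyl in place of amino on an aromatic carbon, and in this assay compound 2 gives 7.5. The step made by that change is a number 0.20 log units higher from compound 1 to compound 2 (within the scatter), so the two numbers are not told apart by this measurement.

Compound 3 `Cc1nc2c(OCc3ccccc3)nccn2c1N` belongs to a different core; how that core differs from the core of compound 1 is not broken down here. In this assay, among the measured compounds shown here, compound 3 gives 4.6, the lowest of the three numbers measured so far: the gap to compound 1 and the gap to compound 2 are both beyond the scatter, with compound 1 the nearer of the two.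

Compound 4 `Cc1nc2c(OCc3ccccc3)nccn2c1C` has not yet been measured. It differs from compound 3 by methyl in place of amino on an aromatic carbon, the same change that separates compound 1 from compound 2, at a place described in the same words. Because that change gave a number 0.20 log units higher from compound 1 to compound 2 (within the scatter) on the core of compound 1, the step from compound 3 to compound 4 is expected to be of similar size, a number 0.20 log units higher from compound 3 to compound 4 (within the scatter). On that basis compound 4 is estimated to give 4.8 in this assay, with a likely range from 4.3 to 5.3. What compound 4 in fact gives remains to be seen.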

Compound 4, acid dissociation constant: 4.8
Estimate against measurement, compound 4: no gap at the digits printed; low and high end bracket the measured number.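

In this assay, methyl in place of amino on an aromatic carbon gives a number 0.20 log units higher from compound 3 to compound 4 (within the scatter), and the same change on the core of compound 1 gave a number 0.20 log units higher from compound 1 to compound 2 (within the scatter), so on both cores the two members of the pair are not told apart by this measurement. What carries from one core to the other is therefore the lack of a resolved step, not a shift of established size, and the agreement between the two steps shows no more than that these two pairs read alike within the scatter. It rests on two cores only, so it sets no rule for other cores in the series, and nothing available here accounts for the agreement.

The compounds shown leave open whether an ethyl group, a methoxy group or a carboxylic acid at this same place, on either core, would give a step beyond the scatter in this assay. Also open, on these data alone, is whether the two pairs would still read alike if a longer chain or an amine took the place of the methyl group on the neighbouring ring atom that bears it.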